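From a Cyclobutyl Ring to an Open Propyl Chain

The compounds below may be only part of what the source reports. "The series", "measured", "known", "first", "only" and "open" are said of these compounds alone.

Three compounds have been measured in an ADME assay on microsomes from liver (Mus musculus, strain NMRI) for metabolic stability, tested at 2.5 uM; on this read-out higher numbers stand for fast clearance and lower numbers for slow clearance:

compound 1, `c1ccc(-c2ccc(Cn3nnc4ccccc43)cc2)cc1`, gives 11.4 mL/min/g
compound 2, `Fc1cc(Cl)ccc1Cn1nnc2c(Br)cccc21`, gives 1.3 mL/min/g
compound 3, `Brc1cccc2c1nnn2CC1CCC1`, gives 11.4 mL/min/g

Compound 3 sits level with compound 1 at the digits shown; the two of them together form the top of this small set, and the difference between them lies within the usual scatter, so no order can be read between them. Compound 2 stands well apart, with a number far lower than that of compound 3, and that gap is beyond the scatter.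

The next compound, compound 4, is `CCCCn1nnc2c(Br)cccc21`. It differs from compound 3 in one place: propyl in place of cyclobutyl on a saturated chain carbon bound to an aromatic nitrogen. The four-membered ring is opened into a short straight chain of one atom fewer, and nothing else in the molecule moves.

Among the measured compounds shown here, no measured pair in this set shows what such a change does, so the expectation rests on compound 3 alone. With a small change of this kind, the number for compound 4 is expected to stay close to the high end seen for compound 3, and the step of a 1.0-fold lower number from compound 3 to compound 4 (0.02 log units; within the scatter) is estimated to lie within the scatter. Compound 4 is therefore expected to give about 11 mL/min/g, within a range from 4.5 mL/min/g to 27 mL/min/g.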

Compound 4, intrinsic clearance in a liver preparation (reported as CLH), per the amount of preparation that the assay uses: 8.3 mL/min/g
Beside the measured number, compound 4's estimate is 1.3-fold (0.12 log units) above it; low and high end bracket the measured number.
By their numbers in this assay, from the lowest: compound 2; then compounds 4, 1 and 3 (each within the scatter of the next).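

In this assay, among the compounds shown here, swapping cyclobutyl for propyl gives a 1.4-fold lower number from compound 3 to compound 4 (0.14 log units; within the scatter) and this is the first direct comparison at this position, since no two earlier compounds differed in only one place. It shows that, on a saturated chain carbon bound to an aromatic nitrogen, the four-membered ring can be opened and one carbon removed with no change that can be told apart from the ordinary spread of repeated measurements. Nothing measured here offers a reason for this outcome.

A single pair cannot show how far this freedom at the position extends: a longer chain, an amine or a carboxylic acid in the same place might leave the clearance equally undisturbed or might move it well beyond the scatter. On these data alone, it also remains open whether the change from cyclobutyl to propyl would give a similarly small step on a different core.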